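From 4-Methylbenzyl to 3-Phenylprop-2-en-1-yl: An Open Step

The compounds below may be only part of what the source reports. "The series", "measured", "known", "first", "only" and "open" are said of these compounds alone.

compound 1 `COc1ccc(C(O)(Cc2ccc(C)cc2)c2cccc3ccccc23)c(OC)c1OC`: > 20000 nM
compound 2 `COc1ccc(/C(=N/OCC(=O)O)c2cccc3ccccc23)c(OC)c1OC`: > 20000 nM

In a functional assay on MCF7 cells (Homo sapiens) for inhibition, read by sulforhodamine B assay, with a stated time of 48 h (on this read-out higher numbers stand for weaker inhibition and lower numbers for stronger inhibition), compound 1 returns only a limit, > 20000 nM. Compound 2 likewise gives only a limit there, > 20000 nM. Compound 1 therefore sits at the limit of > 20000 nM in this assay, at which 2 of the 2 values shown sit, and nothing separates it from compound 2. Compound 3 `COc1ccc(C(O)(C/C=C\c2ccccc2)c2cccc3ccccc23)c(OC)c1OC` differs from compound 1 by 2-phenylethenyl in place of 4-methylphenyl on a saturated chain carbon, two bonds along the chain from two aromatic carbons and an oxygen on a saturated carbon. Within the data shown here, no measured step covers this change, so the writer expects no step beyond the scatter in this assay; the expected step is a number no higher from compound 1 to compound 3 (the limit leaves the size open). For compound 3 the estimate is 20000 nM, with a range from 4000 nM to 80000 nM, and most probably only a limit will again be reported.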

Compound 3, half-maximal inhibitory concentration: 10200 nM
The estimate for compound 3 lay 2.0-fold (0.29 log units) above the measured number; the range from low to high includes it.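

At this place, on a saturated chain carbon, 2-phenylethenyl in place of 4-methylphenyl gives an at least 1.9-fold lower number from compound 1 to compound 3 (0.29 log units; that floor lies within the scatter). In this assay compound 3 is the only one of the three shown to return a number rather than a limit, so a value can now be read for this series. Compound 1 and compound 2 each give only a limit: the limit of > 20000 nM in this assay, at which 2 of the 3 values shown sit.

On these data alone, the true size of the step stays open, since one end of it is a limit. Also open, as far as these compounds go, is whether a saturated 3-phenylpropyl group, or an amine on the phenyl ring, would return a number in this assay.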